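This account rests on a few compounds, and the source may have more. Where it says the series, first, only, none or still open, it means among the compounds named here.

Of the compounds shown here, two sharing one core have been tested in an ADME assay on HEL cells (Homo sapiens), read by cell counting, with a stated time of 3 days; a higher number here means that more compound is tolerated, a lower number that less compound is tolerated. Compound 1, `CCCCCCc1ccc(C#CC#Cc2cn([C@H]3C[C@H](O)[C@@H](CO)O3)c(=O)[nH]c2=O)cc1`, gives 35000 nM in this assay. Compound 2, `COc1cc(C#CC#Cc2cn([C@H]3C[C@H](O)[C@@H](CO)O3)c(=O)[nH]c2=O)cc(OC)c1`, gives only > 100000 nM in this assay, which is a limit and not a number. Where compound 2 stands is therefore known only from the limit of > 100000 nM in this assay, at which 1 of the 2 values shown sits. Compound 3, `Cc1cc(C#CC#Cc2cn([C@H]3C[C@H](O)[C@@H](CO)O3)c(=O)[nH]c2=O)ccc1F`, is not yet measured; it differs from compound 2 in one place: 4-fluoro-3-methylphenyl in place of 3,5-dimethoxyphenyl on a triple-bonded carbon. For the measured compounds named here, no measured pair in the set differs by this same change, so the size of the step is open. With compound 2 sitting at a limit, any real move from compound 2 to compound 3 would have to be a decrease to become visible, and a change beyond the usual scatter is plausible but not assured. Compound 3 is estimated at 60000 nM, within 20000 nM to 150000 nM. The expected step is an at least 1.6-fold lower number from compound 2 to compound 3 (0.22 log units; that floor lies within the scatter).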

Compound 3, half-maximal cytotoxic concentration: 45000 nM
Compound 3: the middle estimate sits 1.3-fold (0.12 log units) above what was measured, within the range that was stated.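

In this assay, the aryl group on the triple-bonded carbon proves able to shift how much compound the cells tolerate: putting 4-fluoro-3-methylphenyl in place of 3,5-dimethoxyphenyl gives an at least 2.2-fold lower number from compound 2 to compound 3 (0.34 log units; beyond the scatter). In this change, a group counted with 2 hydrogen-bond acceptors gives way to one counted with 0, while the six-membered aromatic ring of carbon stays. The full size of the step remains unknown because compound 2 has a limit and not a number: the limit of > 100000 nM in this assay, at which 1 of the 3 values shown sits.

The compounds shown do not separate the loss of the methoxy groups from the arrival of the fluorine and the methyl, as all of this happens in one step. They also leave open how an aryl group carrying an amine or a carboxylic acid would behave at this position.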